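The compounds below may be only part of what the source reports. "The series", "measured", "known", "first", "only" and "open" are said of these compounds alone.

Measured in a functional assay for inhibition, with Homo sapiens as the target; on this read-out lower numbers stand for stronger inhibition and higher numbers for weaker inhibition:
- Compound 1 `COc1ccc2nc(COc3ccc4c(c3)c(SC(C)(C)C)c(CC(C)(C)C(=O)O)n4Cc3ccc(Cl)cc3)sc2c1`: 8 nM
- Compound 2 `CC(C)(C)Sc1c(CC(C)(C)C(=O)O)n(Cc2ccc(Cl)cc2)c2ccc(OCc3nc4ccccc4o3)cc12`: < 7 nM (a limit)
- Compound 3 `CC(C)(C)Sc1c(CC(C)(C)C(=O)O)n(Cc2ccc(Cl)cc2)c2ccc(OCc3cccc(Cl)n3)cc12`: 3 nM

Compound 3 has the lower of the two actual numbers, a 2.7-fold lower number from compound 1 to compound 3 (0.43 log units; beyond the scatter). Against compound 2 the position stays open: a step that the limit leaves unreadable from compound 2 to compound 3.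

Compound 4 `C[C@@H](COc1ccc2c(c1)c(SC(C)(C)C)c(CC(C)(C)C(=O)O)n2Cc1ccc(Cl)cc1)c1ccccn1` brings a new change at the same place: 1-(pyridin-2-yl)ethyl in place of 6-chloropyridin-2-yl on a saturated chain carbon bound to an oxygen on an aromatic ring. Among the compounds with values here, two measured steps bear on it, both at this place: the modest 2.7-fold lower number from compound 1 to compound 3 (0.43 log units; beyond the scatter) and an at least 1.1-fold lower number from compound 1 to compound 2 (0.05 log units; that floor lies within the scatter). Neither tests the new group directly. As compound 3 already sits low at 3 nM, a small upward move is expected in this assay, probably within the scatter: a 1.7-fold higher number from compound 3 to compound 4 (0.22 log units; within the scatter). For compound 4 the estimated value is 5 nM, with an expected range of 1.5 nM to 16 nM.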

Compound 4, half-maximal inhibitory concentration: 2 nM
Compound 4: the middle estimate sits 2.5-fold (0.40 log units) above what was measured; measured number inside the range.
By their numbers in this assay, from the lowest: compounds 4 and 3 (each within the scatter of the next); then compound 1.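

The place on a saturated chain carbon bound to an oxygen on an aromatic ring accepts 1-(pyridin-2-yl)ethyl with its defined stereocentre as readily as 6-chloropyridin-2-yl in this assay (a 1.5-fold lower number from compound 3 to compound 4 (0.18 log units; within the scatter)). Against 6-methoxy-1,3-benzothiazol-2-yl, the new group gives a clear gain (a 4.0-fold lower number from compound 1 to compound 4 (0.60 log units; beyond the scatter)). Steps involving compound 2 cannot be read, as its value is a limit: the limit of < 7 nM in this assay, at which 1 of the 4 values shown sits.

The compounds shown leave open what the opposite configuration at the stereocentre of compound 4 would give. Also open, as far as these compounds go, is how an amine or a longer chain carrying the pyridin-2-yl ring would read at this place.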